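Moving the benzyl substituent: from compound 3 to compound 4

A few compounds are considered here, and "the series" means these few. Any claim that something is new, unique, unknown or untested is made for them only; others in the source may bear on it.

Compound 3 `C/C(C#Cc1ccccc1)=N\N/C(N)=N/S(=O)(=O)c1cc(C)c(Cl)cc1SCc1ccc(C)cc1` carries a 4-methylbenzyl group on the sulfur of the shared core. For the measured compounds named here, in a functional assay on HCT-116 cells (Homo sapiens) for antiproliferative activity, read by MTT assay, with a stated time of 72 h (a higher number here means a weaker inhibitor, a lower number a stronger inhibitor), compound 3 gives 13000 nM, the second highest of the three numbers so far. Its nearest neighbour is compound 1 `C/C(C#Cc1ccccc1)=N\N/C(N)=N/S(=O)(=O)c1cc(C)c(Cl)cc1SCc1ccccc1`, the unsubstituted benzyl analogue, which in this assay gives 10000 nM; the step of a 1.3-fold higher number from compound 1 to compound 3 (0.11 log units; within the scatter) is within the scatter. Compound 2 `C/C(C#Cc1ccccc1)=N\N/C(N)=N/S(=O)(=O)c1cc(C)c(Cl)cc1SCc1ccccc1C`, with the methyl on a different ring carbon, gives 142000 nM in this assay, and the step of an 11-fold lower number from compound 2 to compound 3 (1.04 log units; beyond the scatter) is large.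

Compound 4 `C/C(C#Cc1ccccc1)=N\N/C(N)=N/S(=O)(=O)c1cc(C)c(Cl)cc1SCc1cccc(Cl)c1` introduces (3-chlorophenyl in place of 4-methylphenyl on a saturated chain carbon bound to a sulfur). Going by the values given here, two measured steps bear on it. The step of a 14-fold higher number from compound 1 to compound 2 (1.15 log units; beyond the scatter) shows that a methyl at one ring position sharply raises the number, while a 1.3-fold higher number from compound 1 to compound 3 (0.11 log units; within the scatter) shows that the same methyl elsewhere changes little; so the outcome depends strongly on where the substituent sits. On these data alone, no chlorine-bearing benzyl has been measured, and the 3-position is untested, so the direction is uncertain; a moderate rise, within or just beyond the scatter, seems the most balanced expectation.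

For compound 4 the expected value in this assay is 18000 nM, with a range from 6000 nM to 60000 nM. The expected step is a 1.4-fold higher number from compound 3 to compound 4 (0.14 log units; within the scatter).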

Compound 4, half-maximal inhibitory concentration: 119000 nM
Compound 4: the middle estimate sits 6.6-fold (0.82 log units) below what was measured, outside the stated range (above it).
By their numbers in this assay, from the lowest: compounds 1 and 3 (each within the scatter of the next); then compounds 4 and 2 (each within the scatter of the next).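

In this assay the large rise at this position is no longer tied to a methyl group: a 9.2-fold higher number from compound 3 to compound 4 (0.96 log units; beyond the scatter) and a 12-fold higher number from compound 1 to compound 4 (1.08 log units; beyond the scatter) show that 3-chlorophenyl on a saturated chain carbon bound to a sulfur also takes the number beyond the scatter. With a 1.2-fold lower number from compound 2 to compound 4 (0.08 log units; within the scatter), compound 2 and compound 4 stand level, so 2-methylphenyl and 3-chlorophenyl give equivalent results despite carrying different substituents at different ring positions, while compound 3 goes against any reading that a ring substituent on the benzyl always raises the number. No measurement at hand explains this rise.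

On these data alone, whether the rise follows the chlorine or its ring position remains open, and a 4-chlorobenzyl or a 3-methylbenzyl on the sulfur would separate the two. For the compounds shown here, also open is whether a 4-methoxybenzyl or a plain alkyl chain in the same place could bring the number below that of compound 1 at 10000 nM, the low end of the series so far together with compound 3.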